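The source may hold more compounds than are shown below. What is called first, only, known or untested is meant among the compounds shown, and "the series" means these compounds.

Among the measured compounds shown here, in a physicochemical assay for solubility, with a stated time of 24 h, tested at 30 mg/mL (a higher number here means a more soluble compound, a lower number a less soluble compound), three compounds with a shared core have numbers so far. Compound 1 `O=C(CCCCNc1c(Nc2ccccc2)c(=O)c1=O)NO` stands at 32000000 nM and compound 3 `CC[C@H](Nc1c(NCCCCCC(=O)NO)c(=O)c1=O)c1ccccc1` stands at 57000000 nM while compound 2 `O=C(CCCCCNc1c(NCc2ccccc2)c(=O)c1=O)NO` is the lowest of the three at 5700000 nM on this scale. Compound 4 `Cc1ccccc1Nc1c(NCCCCCC(=O)NO)c(=O)c1=O` has not been measured yet. It holds the same atoms as compound 2 joined differently, and the change is 2-methylphenyl in place of benzyl on a nitrogen on an aromatic ring with 2-methylphenyl in place of benzyl on a nitrogen on an aromatic ring.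

For the measured compounds named here, only one measured step touches this part of the molecule: a 10-fold higher number from compound 2 to compound 3 (1.00 log units; beyond the scatter) for ethyl in place of hydrogen on a saturated chain carbon bound to an aromatic carbon and a nitrogen on an aromatic ring. That is a different change, so it shows only that one edit here moved the number by a modest amount. Compound 1 at 32000000 nM also has an aromatic ring bound directly to that nitrogen, yet it differs from compound 4 elsewhere too and is only a loose guide.

A modest rise is therefore expected, smaller than the measured step and resting on thin evidence. The estimated change is a 2.6-fold higher number from compound 2 to compound 4 (0.42 log units; beyond the scatter) in this expected direction. For compound 4 the estimated value is 15000000 nM with an expected range from 4000000 nM to 50000000 nM once it is measured.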

Compound 4, solubility: 12000000 nM
Compound 4: middle estimate off by 1.3-fold (0.10 log units), on the high side; measured number inside the range.
By their numbers in this assay, from the lowest: compound 2; then compound 4; then compounds 1 and 3 (each within the scatter of the next).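

In this assay, the change from benzyl to 2-methylphenyl on this nitrogen gives a 2.1-fold higher number from compound 2 to compound 4 (0.32 log units; beyond the scatter), and here no atoms are added or lost. Both groups have the same count of heavy atoms, one six-membered aromatic ring of carbon only and no hydrogen-bond donors or acceptors, so rearranging the same atoms at this position is enough to move the number beyond the usual scatter, whereas the earlier step at this part of the molecule added an ethyl group. Nothing measured here explains this rise.

The compounds shown do not separate the two parts of this change: the methyl group, and the replacement of benzyl by an aromatic ring bound directly to the nitrogen, as a plain phenyl group on the chain of compound 4 would do. They also leave open how the number would respond to a different kind of substituent on this ring, such as an amine or a carboxylic acid, or to a pyridine ring in place of the carbon-only ring.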